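A few compounds are considered here, and "the series" means these few. Any claim that something is new, unique, unknown or untested is made for them only; others in the source may bear on it.

Compounds measured so far:

compound 1, `CNc1nc(-c2ccccc2)nc2c1nnn2Cc1ccccc1Cl`, 191000000 nM
compound 2, `FC(F)(F)c1ccccc1Cn1nnc2c(NC3CCCCC3)nc(-c3ccccc3)nc21`, 6800000 nM
compound 3, `CCCCCCNc1nc(-c2ccccc2)nc2c1nnn2Cc1ccccc1`, 13200000 nM

In an assay on isolated protein for binding affinity to adenosine receptor A1 (Bos taurus) (on this read-out higher numbers stand for weaker inhibition and lower numbers for stronger inhibition), compound 2 gives the lowest of the three numbers. Compound 3 stands nearest to it, with a number that lies within the usual scatter of compound 2, so no order between the two can be claimed. Compound 1 lies far beyond the scatter from compound 2, with a much higher number. Compound 4, `Fc1ccccc1Cn1nnc2c(NC3CCCCC3)nc(-c3ccccc3)nc21`, has not yet been measured in this assay. It differs from compound 2 in one place: fluoro in place of trifluoromethyl on an aromatic carbon. Among the compounds with values here, no pair among the measured compounds shows this change, so the size of the step has to be estimated rather than read off. The three compounds at hand differ in more than one place at a time, and none of them isolates a substituent on that ring. The step from compound 2 to compound 4 is therefore expected to be small, most likely within the scatter, with the direction uncertain: a 1.2-fold higher number from compound 2 to compound 4 (0.07 log units; within the scatter). For compound 4 in this assay the value is expected near 8000000 nM, within a range from 2000000 nM to 32000000 nM.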

Compound 4, inhibition constant: 1150000 nM
Compound 4: middle estimate off by 7.0-fold (0.84 log units), on the high side; the whole stated range lies above it.
By their numbers in this assay, from the lowest: compound 4; then compounds 2 and 3 (each within the scatter of the next); then compound 1.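

In this assay, within the data shown here, exchanging 2-(trifluoromethyl)benzyl for 2-fluorobenzyl gives a 5.9-fold lower number from compound 2 to compound 4 (0.77 log units; beyond the scatter), the first step here that isolates a change in one place. It shows that the substituent at this aromatic carbon affects the number: a group of four heavy atoms gives way to a single fluorine, with no hydrogen-bond donor, acceptor or net charge on either side, and the step still lies beyond the scatter. Nothing available explains the step, which remains an observation from a single pair of compounds.

From the compounds shown here alone, it remains open whether hydrogen, chloro, methyl or methoxy at this carbon would extend the same trend or break it. Going by these compounds, it is also open whether the same exchange would have a similar effect with the methylamino or hexylamino group in place of the cyclohexylamino group.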